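The source may report more compounds than this note shows. Statements on the series, on what has been measured and on what is new or still open speak of the compounds shown alone.

Working notes on the series. Three compounds of the shared core have numbers in a functional assay on PC-3 cells (Homo sapiens) for inhibition, read by sulforhodamine B assay, with a stated time of 48 h (on this read-out lower numbers stand for higher toxicity in this test and higher numbers for lower toxicity in this test), so far. Compound 1 `Nc1cc(N)c2nc(-c3ccccc3)c(NCc3ccc(F)cc3)nc2c1` carries a (4-fluorobenzyl)amino group. In this assay compound 1 gives only a limit, < 100000 nM, as the limit of < 100000 nM in this assay, at which 1 of the 3 values shown sits, records. Compound 2 `COc1ccc(Sc2nc3cc(N)cc(N)c3nc2-c2ccccc2)cc1` carries a (4-methoxyphenyl)sulfanyl group, and in this assay compound 2 gives 19100 nM. Compound 3 `Nc1cc(N)c2nc(-c3ccccc3)c(Oc3ccc(F)cc3)nc2c1` carries a 4-fluorophenoxy group, and in this assay compound 3 gives 83200 nM. Going by the values given here, compound 3 thus stands at the highest of the two readable numbers, with compound 2 the nearest, a step of a 4.4-fold higher number from compound 2 to compound 3 (0.64 log units; beyond the scatter) being the one readable step in the set. The steps a step that the limit leaves unreadable from compound 1 to compound 2 and a step that the limit leaves unreadable from compound 1 to compound 3 cannot be sized.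

Compound 4 `Nc1cc(N)c2nc(-c3ccccc3)c(Sc3ccc(F)cc3)nc2c1` is not yet measured. It differs from compound 3 in one place: (4-fluorophenyl)sulfanyl in place of 4-fluorophenoxy on an aromatic carbon. Among the compounds with values here, the only measured step that bears on this change is the one from compound 2 to compound 3, in which a sulfanyl-linked aryl group was exchanged for an oxygen-linked one with a move to the higher number. Reversing the linker while keeping the fluorine is therefore expected to move the number down, by a step of about a 2.8-fold lower number from compound 3 to compound 4 (0.44 log units; beyond the scatter). The estimate for compound 4 in this assay is 30000 nM, within a range of 10000 nM to 90000 nM.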

Compound 4, concentration lethal to 50% of the cells: < 100000 nM
Compound 4 gave a limit, no number; the forecaster's own chance of this, stated with the estimate: 15%; the middle value lies beyond the limit too.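

Going by these compounds alone, compound 4 gives < 100000 nM in this assay and this is a limit, so no new step from compound 1, compound 2 or compound 3 to compound 4 can be read. The compounds shown leave open whether, and in which direction, (4-fluorophenyl)sulfanyl in place of 4-fluorophenoxy, or fluoro in place of methoxy, moves the number.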